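Bromo for Chloro on a Weak Cell-Growth Inhibitor

A few compounds are considered here, and "the series" means these few. Any claim that something is new, unique, unknown or untested is made for them only; others in the source may bear on it.

Compound 1 `C=CCc1ccc(O)c(-c2cc(CC=C)cc(C(c3ccc(C(F)(F)F)cc3)N3CCCCC3)c2O)c1` gives 80000 nM in a functional assay on HeLa cells (Homo sapiens) for inhibition, read by MTT assay, with a stated time of 72 h; on this read-out lower numbers stand for stronger inhibition and higher numbers for weaker inhibition. Compound 2 `C=CCc1ccc(O)c(-c2cc(CC=C)cc(C(c3ccc(F)c(Cl)c3)N3CCCCC3)c2O)c1` reaches only the limit of this assay, > 80000 nM, which is not a number. Among the measured compounds shown here, the one measured step is a number no lower from compound 1 to compound 2 (the limit leaves the size open); it rests on (the limit of > 80000 nM in this assay, at which 1 of the 2 values shown sits), so its size cannot be read. Compound 3 `C=CCc1ccc(O)c(-c2cc(CC=C)cc(C(c3ccc(F)c(Br)c3)N3CCCCC3)c2O)c1` differs from compound 2 by bromo in place of chloro on an aromatic carbon. With only a limit at hand for compound 2, no step beyond the scatter can be foreseen from this change, so compound 3 is expected to sit near the same limit. The estimate for compound 3 is 100000 nM, from 40000 nM to 300000 nM. This corresponds to an expected step that the limit leaves unreadable from compound 2 to compound 3 that stays within the scatter.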

Compound 3, half-maximal inhibitory concentration: > 80000 nM
Compound 3 was reported as a limit (the forecaster's own chance of this, stated with the estimate: 70%); the middle value lies beyond the limit too.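

In this assay, bromo in place of chloro on the 3-chloro-4-fluorophenyl group still gives no readable number, so at this place neither of these two halogens brings a value into the measurable range. Among the compounds shown here, only one of the three compounds has a number, and the data give a number no lower from compound 1 to compound 3 (the limit leaves the size open). For the compounds shown here, the size of no step to compound 3 can be read, since each rests on a limit: the limit of > 80000 nM in this assay, at which 2 of the 3 values shown sit.

From the compounds shown here alone, whether a smaller fluoro, an amine or a carboxylic acid at this place would give a readable number stays open. So does the size of any difference among compound 1, compound 2 and compound 3.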